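Compound 3: 4-chlorophenyl in place of 3-chlorophenyl

A few compounds are considered here, and "the series" means these few. Any claim that something is new, unique, unknown or untested is made for them only; others in the source may bear on it.

compound 1 `CC(=O)SCCC(CCCCC(=O)Nc1ccccc1Cl)SC(C)=O` gives 2.48%
compound 2 `CC(=O)SCCC(CCCCC(=O)Nc1cccc(Cl)c1)SC(C)=O` gives 0.27%
compound 3 `CC(=O)SCCC(CCCCC(=O)Nc1ccc(Cl)cc1)SC(C)=O` has not yet been measured

Going by the values given here, in a functional assay on HO8910 cells (Homo sapiens) for inhibition, read by MTT assay, with a stated time of 24 h, tested at 0.1 ug/mL (on this read-out higher numbers stand for more inhibition of growth at the one concentration tested and lower numbers for less inhibition of growth), compound 2 gives 0.27% and stands within the scatter of compound 1, the only other measured compound. Compound 3 differs from compound 2 in one place (4-chlorophenyl in place of 3-chlorophenyl on an amide-type nitrogen) with 4-chlorophenyl in place of 3-chlorophenyl on an amide-type nitrogen. Among the compounds with values here, the one measured step of like kind, 3-chlorophenyl in place of 2-chlorophenyl on an amide-type nitrogen, is a number 2.2 percentage points lower from compound 1 to compound 2 (within the scatter) and gives no ground for expecting a large move. In this assay the expected result is a number 1.2 percentage points higher from compound 2 to compound 3 (within the scatter) with nothing beyond the scatter. Compound 3 is estimated at 1.5% within an expected range (-2% to 8%).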

Compound 3, percent growth inhibition at one concentration: 1.81%
Beside the measured number, compound 3's estimate is 0.3 percentage points below it, within the range that was stated.
By their numbers in this assay, from the lowest: compounds 2, 3 and 1 (each within the scatter of the next).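

In this assay, 4-chlorophenyl on an amide-type nitrogen gives a number 1.5 percentage points higher from compound 2 to compound 3 (within the scatter) and a number 0.7 percentage points lower from compound 1 to compound 3 (within the scatter) when it takes the place of 3-chlorophenyl and of 2-chlorophenyl. With all three chlorophenyl isomers now in hand, moving the chlorine around this ring separates none of them at the one concentration tested. No further data explain this result. The compounds shown leave open whether another group on that nitrogen, such as a 4-methoxyphenyl or a 4-carboxyphenyl, would read differently. They also leave open whether a longer chain in the shared core would change the reading.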